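Swapping the aryl arm: from thiophene to fluorophenyl

This account rests on a few compounds, and the source may have more. Where it says the series, first, only, none or still open, it means among the compounds named here.

Compound 1 `O=Cc1ccc(-c2cn3ccnc3c(-c3ccc4ncn(C5CCCCC5)c4c3)n2)cc1`: 56.5%
Compound 2 `Fc1ccc(-c2cn3ccnc3c(-c3ccc4ncn(C5CCCCC5)c4c3)n2)cc1`: 7.36%
Compound 3 `c1cn2cc(-c3ccsc3)nc(-c3ccc4ncn(C5CCCCC5)c4c3)c2n1`: 25%

These three compounds were tested in a functional assay on SK-MEL-5 cells (Homo sapiens) for inhibition, read by sulforhodamine B assay, with a stated time of 48 h, tested at 10 uM; a lower number here means less inhibition, a higher number more inhibition at the concentration tested (going by the name of the read-out). Compound 3 stands second highest of the three; its nearest neighbour is compound 2, and compound 1 stands furthest from it, as a number 31.5 percentage points lower from compound 1 to compound 3 (beyond the scatter) shows.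

Compound 4 `Fc1ccccc1-c1cn2ccnc2c(-c2ccc3ncn(C4CCCCC4)c3c2)n1` has not yet been measured. It differs from compound 3 in one place: 2-fluorophenyl in place of thiophen-3-yl on an aromatic carbon.

The step that bears most on this change is a number 17.6 percentage points higher from compound 2 to compound 3 (beyond the scatter), which shows how a fluorophenyl arm compares with the thiophen-3-yl arm. Compound 4 carries a fluorophenyl arm again, so a downward step from compound 3 of modest size is expected, a number 13 percentage points lower from compound 3 to compound 4 (beyond the scatter). Compound 4 is therefore estimated at 12%, within a range of 0% to 35%.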

Compound 4, a percentage reported as inhibition, at one concentration (the size of the read-out at that concentration, not a potency): 6.5%
Beside the measured number, compound 4's estimate is 5.5 percentage points above it; the measured number falls inside the stated range.
By their numbers in this assay, from the lowest: compounds 4 and 2 (each within the scatter of the next); then compound 3; then compound 1.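

In this assay the 2-fluorophenyl and 4-fluorophenyl arms cannot be told apart (a number 0.9 percentage points lower from compound 2 to compound 4 (within the scatter)), so at this position the two fluorophenyl arms give the same reading. The 2-fluorophenyl arm also stands beyond the scatter under the thiophen-3-yl arm (a number 18.5 percentage points lower from compound 3 to compound 4 (beyond the scatter)) and the 4-formylphenyl arm (a number 50 percentage points lower from compound 1 to compound 4 (beyond the scatter)), which leaves the formyl-bearing arm alone at the top of the four. No measurement shown accounts for these differences.

From the compounds shown here alone, whether a hydroxymethyl group or a carboxylic acid in place of the formyl group would keep the reading of compound 1 stays open.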